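Swapping the aryl methyl pattern in a metabolic stability series

A few compounds are considered here, and "the series" means these few. Any claim that something is new, unique, unknown or untested is made for them only; others in the source may bear on it.

Compound 1 `Cc1cc(C)c(-c2nc(CN3CCC(C(=O)NCCCN4C[C@H](C)C[C@H](C)C4)CC3)c(C)o2)c(C)c1` was examined in an ADME assay on microsomes from liver (Rattus norvegicus) for metabolic stability, read by LC-MS, using NADPH, at 37 degrees C; a lower number here means that the compound disappears faster, a higher number that the compound lasts longer. In this assay compound 1 gives > 0.5 h, which is a limit of the assay and not a number. Compound 3 `CCCN(CCC)CCNC(=O)C1CCN(Cc2nc(-c3ccccc3C)oc2C)CC1` likewise sits at a limit, with > 0.5 h. Compound 2 `Cc1ccccc1-c1nc(CN2CCC(C(=O)NCCCN3CCCC(C(C)C)C3)CC2)c(C)o1` gives 0.323 h. Within the data shown here, the one measured step, an at least 1.5-fold higher number from compound 2 to compound 3 (0.18 log units; that floor lies within the scatter), concerns the amine end of the chain rather than the aromatic ring, and its floor lies within the scatter; the limit of > 0.5 h in this assay, at which 2 of the 3 values shown sit, marks where two of the three values sit. Compound 4 `Cc1ccc(-c2nc(CN3CCC(C(=O)NCCCN4C[C@H](C)C[C@H](C)C4)CC3)c(C)o2)cc1C` differs from compound 1 by 3,4-dimethylphenyl in place of 2,4,6-trimethylphenyl on an aromatic carbon. Among the measured compounds shown here, no measured step touches this aromatic ring, and the account therefore has no measured size to borrow for it; the expectation is that the change leaves the half-life within the scatter of compound 1. For compound 4 the estimated half-life is 0.5 h, with a range from 0.25 h to 1 h. The step this estimate means, a number no higher from compound 1 to compound 4 (the limit leaves the size open), is expected to be small.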

Compound 4, half-life: > 0.5 h
Compound 4: a limit, no number; the forecaster's own chance of this, stated with the estimate: 50%; the middle value lies on the limit itself.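

In this assay compound 4 gives > 0.5 h, which is a limit of the assay and not a number. Among these compounds, compound 1 also sits at a limit, so no step between compound 1 and compound 4 can be read. The compounds shown leave open how the half-lives with 3,4-dimethylphenyl and 2,4,6-trimethylphenyl compare.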